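This account rests on a few compounds, and the source may have more. Where it says the series, first, only, none or still open, it means among the compounds named here.

Within the data shown here, compound 1 `Cc1ccc(C(=O)CSc2nc3ccccc3[nH]2)cc1` is one of two compounds measured so far in a functional assay on HT-29 cells (Homo sapiens) for inhibition, read by flow cytometry, tested at 10 uM (a higher number here means more inhibition at the concentration tested (going by the name of the read-out), a lower number less inhibition), where compound 1 gives 40%. Compound 2 `COc1ccc(C(=O)CSc2nc3ccccc3[nH]2)cc1O` gives in this assay a value of 49.7%. The value of compound 1 is the lower of the two numbers, but the gap to compound 2 lies within the scatter of repeated measurements, so the two compounds cannot be told apart on this basis, and no direction is read from them.

Compound 3 `O=C(CSc1nc2ccccc2[nH]1)c1ccccc1` has not yet been measured in this assay. Its structural change from compound 1 is hydrogen in place of methyl on an aromatic carbon. Among the measured compounds shown here, no step between two measured compounds in the set shares this change, so there is nothing of this kind to lean on; the expectation for compound 3 rests on compound 1 alone.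

With the removal of one carbon and no change in donors, acceptors or charge, the step from compound 1 to compound 3 is expected to be small, and a number 2 percentage points lower from compound 1 to compound 3 (within the scatter) is the expected step, not beyond the scatter in either direction. For compound 3 an inhibition of 38% is estimated, with a range from 20% to 56%.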

Compound 3, a percentage reported as inhibition, at one concentration (the size of the read-out at that concentration, not a potency): "not active" (no number reported)
Nothing numeric was reported for compound 3, and the estimate cannot be compared.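

Among these compounds, compound 3 is reported as "not active" in this assay, without a number, so no step from compound 1 to compound 3 can be read. The compounds shown leave open how large any difference in inhibition between compound 3 and compound 1 is, and whether the methyl matters. No measured evidence bears on this result.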